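This account rests on a few compounds, and the source may have more. Where it says the series, first, only, none or still open, it means among the compounds named here.

In an ADME assay on MT4 cells (Homo sapiens) for cytotoxicity, read by MTT assay, with a stated time of 4 days (on this read-out higher numbers stand for lower toxicity in this test and lower numbers for higher toxicity in this test), three compounds built on one shared core have been tested. Compound 1 `CCOC(=O)c1cnc(N2CCN(Cc3cccc(C(F)(F)F)c3)CC2)nc1Oc1c(C)cc(-c2ccc(C#N)cc2)cc1C` gives > 125000 nM, which is a limit of the assay and not a number. Compound 2 `CCOC(=O)c1cnc(N2CCN(Cc3ccccc3F)CC2)nc1Oc1c(C)cc(-c2ccc(C#N)cc2)cc1C` gives > 125000 nM, again a limit rather than a number. Compound 3 `CCOC(=O)c1cnc(N2CCN(Cc3ccccc3C(=O)OC)CC2)nc1Oc1c(C)cc(-c2ccc(C#N)cc2)cc1C` gives > 125000 nM, also a limit. Compound 2 thus stands exactly where every value shown sits, at the limit of > 125000 nM in this assay, at which 3 of the 3 values shown sit, so no value separates it from its neighbours. The steps among the three are a step that the two limits leave unreadable from compound 1 to compound 2, a step that the two limits leave unreadable from compound 1 to compound 3 and a step that the two limits leave unreadable from compound 2 to compound 3; each swaps the group on a saturated chain carbon bound to an amine nitrogen in a ring, and none could be sized.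

Compound 4 `CCOC(=O)c1cnc(N2CCN(Cc3cccc(C(N)=O)c3)CC2)nc1Oc1c(C)cc(-c2ccc(C#N)cc2)cc1C` has not yet been measured. Relative to compound 2 the change is 3-carbamoylphenyl in place of 2-fluorophenyl on a saturated chain carbon bound to an amine nitrogen in a ring. All three measured steps bear on this move, since each changed the same benzyl group without giving a readable shift. The step from compound 2 to compound 4 is therefore expected to be a step that the limit leaves unreadable from compound 2 to compound 4, nothing beyond the scatter. Compound 4 is estimated at 150000 nM, within 70000 nM to 300000 nM, and most likely reported again only as a limit.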

Compound 4, half-maximal cytotoxic concentration: 14800 nM
Beside the measured number, compound 4's estimate is 10-fold (1.01 log units) above it; the measured number lies below the stated range.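

In this assay, among these compounds, the benzyl group on the saturated chain carbon bound to an amine nitrogen in a ring now proves able to move the read-out, and a lower number here means higher toxicity in this test: 3-carbamoylbenzyl gives the only readable number in the set, with an at least 8.4-fold lower number from compound 2 to compound 4 (0.92 log units; beyond the scatter) and an at least 8.4-fold lower number from compound 3 to compound 4 (0.92 log units; beyond the scatter). The tightest comparison is an at least 8.4-fold lower number from compound 1 to compound 4 (0.92 log units; beyond the scatter), where carbamoyl stands in place of trifluoromethyl on an aromatic carbon and the rest of the structure stays the same. These three steps are minimum sizes, because compound 1, compound 2 and compound 3 each stop at a limit of the assay and not at a number: the limit of > 125000 nM in this assay, at which 3 of the 4 values shown sit.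

As far as these compounds go, the steps among compound 1, compound 2 and compound 3 cannot be read, so how far these three truly differ from one another, or from compound 4, stays open. Also open, from the compounds shown here alone, is whether the carbamoyl group is special at this place, or whether a carboxylic acid, an amine or a longer chain ending in a carbamoyl group would lower the number as well.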